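The compounds below may be only part of what the source reports. "The series", "measured", "known", "first", "only" and "open" are said of these compounds alone.

Measured compounds in the series:
compound 1 `COc1ccc(-c2cc(-c3cccc(S(C)(=O)=O)c3)cnc2N)cn1` — in a physicochemical assay for solubility, read by nephelometry, measured as kinetic solubility, at pH 2 (on this read-out lower numbers stand for lower solubility and higher numbers for higher solubility), compound 1 gives > 100 ug/mL, which is a limit of the assay.
compound 2 `COc1ccc(-c2cc(-c3ccc(S(N)(=O)=O)cc3)cnc2N)cn1` — in this assay compound 2 gives > 100 ug/mL, again a limit of the assay, not a number.

Going by the values given here, compound 2 thus stands at the upper limit of the read-out; both values recorded so far sit there (the limit of > 100 ug/mL in this assay, at which 2 of the 2 values shown sit), so no ordering between compound 1 and compound 2 can be read from them, and no step between measured compounds is available.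

The next compound is compound 3 `COc1ccc(-c2cc(-c3ccc(-n4cncn4)cc3)cnc2N)cn1`. It differs from compound 2 by 1H-1,2,4-triazol-1-yl in place of sulfamoyl on an aromatic carbon. With both measured values at the limit, the step cannot be calibrated from within the series. The expectation for compound 3 is that it remains at or near the limit, with the step of a number no higher from compound 2 to compound 3 (the limit leaves the size open) estimated as no more than the usual scatter and most likely again reported as a limit. Compound 3 is estimated at 100 ug/mL, within 30 ug/mL to 200 ug/mL.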

Compound 3, solubility: > 100 ug/mL
Compound 3: no number, only a limit; the forecaster's own chance of this, stated with the estimate: 60%; the middle value lies on the limit itself.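

In this assay compound 3 gives > 100 ug/mL as a limit of the assay, not a number. Going by these compounds alone, no step from compound 2 to compound 3 can be read, since the values sit at the same limit: the limit of > 100 ug/mL in this assay, at which 3 of the 3 values shown sit. The compounds shown leave open how compound 1, compound 2 and compound 3 actually compare in this assay, and what change to the shared core would bring a value inside the measurable range.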